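A Bromophenyl Group Replaces Piperidine on the Shared Core

The source may report more compounds than this note shows. Statements on the series, on what has been measured and on what is new or still open speak of the compounds shown alone.

compound 1 `O=[N+]([O-])c1cccc(CNc2cc(C(F)(F)F)cc3[nH]ncc23)c1` 60%
compound 2 `O=C(O)c1cccc(CNc2cc(C(F)(F)F)cc3[nH]ncc23)c1` 81%
compound 3 `FC(F)(F)c1cc(NC[C@@H]2CCCCN2)c2cn[nH]c2c1` 64%

Of the compounds shown here, three sharing one core have been measured in an assay for inhibition of Tryptophan 2,3-dioxygenase (Homo sapiens), with stated times of 10 min and 60 min, tested at 10 uM; a lower number here means a weaker effect, a higher number a stronger effect of the compound at the concentration tested. Compound 3 stands second highest of the three: compound 1 lies nearest, giving 60%, a gap within the scatter, and compound 2 lies furthest, giving 81%, a gap beyond it.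

Compound 4 `FC(F)(F)c1cc(NCc2cccc(Br)c2)c2cn[nH]c2c1` differs from compound 3 in one place: 3-bromophenyl in place of piperidin-2-yl on a saturated chain carbon bound to a nitrogen on an aromatic ring. Within the data shown here, the only measured step, a number 21 percentage points higher from compound 1 to compound 2 (beyond the scatter), exchanges one substituent for another on an aromatic ring that already sits on the saturated chain carbon; it does not itself replace a saturated ring with an aromatic one, so no measured step bears directly on this change. What the values do show is that compounds 1 and 2, each carrying a substituted aromatic ring on that chain carbon, and compound 3, carrying piperidin-2-yl there, all fall in a fairly narrow band in this assay.

Compound 4 is therefore expected to land close to that band, with a number 2 percentage points higher from compound 3 to compound 4 (within the scatter) likely not clearly beyond the scatter. The estimate for compound 4 is 66%, between 45% and 85%.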

Compound 4, a percentage reported as inhibition, at one concentration (the size of the read-out at that concentration, not a potency): 67%
Compound 4: the middle estimate sits 1 percentage points below what was measured; measured number inside the range.
By their numbers in this assay, from the lowest: compounds 1, 3 and 4 (each within the scatter of the next); then compound 2.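

In this assay, 3-bromophenyl in place of piperidin-2-yl on a saturated chain carbon bound to a nitrogen on an aromatic ring gives a number 3 percentage points higher from compound 3 to compound 4 (within the scatter), so this position takes either ring without a change that can be told from the scatter, even though the hydrogen-bond donor, the hydrogen-bond acceptor and the defined stereocentre counted for piperidin-2-yl all leave. On the aromatic ring, bromo in place of carboxy gives a number 14 percentage points lower from compound 2 to compound 4 (beyond the scatter), while bromo in place of nitro gives a number 7 percentage points higher from compound 1 to compound 4 (within the scatter), which sets the carboxy group of compound 2 apart from both the nitro and the bromo group among these compounds. Nothing at hand accounts for either result.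

From the compounds shown here alone, it remains open whether a carboxylic acid placed on the piperidine ring of compound 3 would match the higher number of compound 2, and whether an amide or a tetrazole in place of carboxy would do the same. Going by these compounds, the effect of a longer chain between the ring nitrogen-bearing carbon and the aromatic core, and of the opposite stereocentre in the piperidin-2-yl group, also remains unknown.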